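From Pyrrolidin-1-yl to Piperidin-1-yl at an Assay Limit

The source may report more compounds than this note shows. Statements on the series, on what has been measured and on what is new or still open speak of the compounds shown alone.

This study follows one small structural change through a functional assay on the whole organism for inhibition, with Mus musculus as the target; on this read-out lower numbers stand for an effect already at smaller amounts and higher numbers for an effect only at larger amounts of compound. Compound 1 (`CCC(=O)c1ccc2c(c1)sc(=O)n2CCN1CCCC1`) carries a pyrrolidin-1-yl group at the end of its side chain. For compound 1 the result is only a limit, not a number: > 80 mg/kg. Its exact place on the scale is therefore unknown. Compound 2 (`CCCCCc1ccc2nc(O)sc2c1`) has a different structure and gives an actual number, 90.5 mg/kg.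

The next compound to be tested is compound 3 (`CCC(=O)c1ccc2c(c1)sc(=O)n2CCN1CCCCC1`), which has piperidin-1-yl in place of pyrrolidin-1-yl on a saturated chain carbon, two bonds along the chain from an aromatic nitrogen. Both groups are non-aromatic rings with no net charge, and the rest of the molecule stays the same. Going by the values given here, no measured pair in this set shows what such a swap does, so any forecast is rough.

The limit of > 80 mg/kg for compound 1 is the only anchor for this forecast. The expected step that the limit leaves unreadable from compound 1 to compound 3 is no larger than the usual scatter, with no clear direction. Compound 3 is estimated at 100 mg/kg, with an expected range of 50 mg/kg to 200 mg/kg.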

Compound 3, dose for half-maximal effect: > 55 mg/kg
Compound 3 gave a limit, no number (the forecaster's own chance of this, stated with the estimate: 50%); the middle value does not contradict the limit.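

Compound 1 and compound 3 each give only a limit in this assay, not a number, so the change from pyrrolidin-1-yl to piperidin-1-yl between them cannot be read as a step of any size or direction. The compounds shown leave open what this swap does to the dose needed for half-maximal effect.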